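This account rests on a few compounds, and the source may have more. Where it says the series, first, only, none or still open, it means among the compounds named here.

In a physicochemical assay for lipophilicity, at pH 7.4 (on this read-out higher numbers stand for higher lipophilicity and lower numbers for lower lipophilicity), compound 1 `Cc1cc(C(=O)NN2CCOCC2)nn1Cc1cc(Cl)ccc1OCC(C)C` gives 3.1. Compound 2 `Cc1cc(NC(=O)C2CCCCC2)nn1Cc1cc(Cl)ccc1OCC(C)C` carries (cyclohexylcarbonyl)amino in place of (morpholin-4-yl)carbamoyl on an aromatic carbon. Compound 2 is reported only as a limit, > 3.7, and not as a number.

Compound 3 `Cc1cc(NC(=O)C2CCCC2)nn1Cc1cc(Cl)ccc1OCC(C)C` keeps the rest of compound 2 and alters only the ring on a carbonyl carbon: cyclopentyl in place of cyclohexyl on a carbonyl carbon. Among the compounds with values here, only one measured step bears on this change, and it is open-ended and beyond the scatter: a number at least 0.60 log units higher from compound 1 to compound 2 (beyond the scatter). That step exchanged a whole substituent, whereas the groups now swapped are both rings of carbon only with no net charge, so its size is not carried over. No step beyond the scatter is therefore expected in this assay, with a small fall as the likelier direction. The expected change is a step that the limit leaves unreadable from compound 2 to compound 3. For compound 3 the estimated value is 3.8, with an expected range of 3.4 to 4.2. The reading for this compound may also turn out to be only a limit.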

Compound 3, distribution coefficient: > 3.7
Compound 3: only a limit was reported; the forecaster's own chance of this, stated with the estimate: 55%; the middle value is on the limit's open side.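

On the exchange of (morpholin-4-yl)carbamoyl for (cyclopentylcarbonyl)amino on an aromatic carbon, this assay gives a number at least 0.60 log units higher from compound 1 to compound 3 (beyond the scatter) and so repeats what the cyclohexyl compound showed. The higher reading therefore does not depend on the six-membered ring: with compound 2 and compound 3 it holds for both ring sizes on the carbonyl carbon, and neither goes against it. Compound 3 is reported only as a limit (> 3.7) and not as a number. The step from compound 2 to compound 3 cannot be read, because both compounds stand at the same limit: the limit of > 3.7 in this assay, at which 2 of the 3 values shown sit.

On these data alone, whether cyclopentyl and cyclohexyl on a carbonyl carbon differ at all in this assay therefore stays open, and so does how far either compound lies from the limit. Also open, as far as these compounds go, is what a smaller ring such as cyclopropyl, or a ring carrying an amine or a carboxylic acid, would give at the same place, and whether any of these would return the reading to a plain number.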